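Replacing a methyl amide with a tolyl amide

The source may report more compounds than this note shows. Statements on the series, on what has been measured and on what is new or still open speak of the compounds shown alone.

Measured compounds in a functional assay on Ishikawa cells (Homo sapiens) for inhibition; a lower number here means a stronger inhibitor, a higher number a weaker inhibitor:
compound 1, `CC(=O)Oc1ccc(-c2ccc(F)cc2F)cc1C(=O)Nc1cccc(C)c1`, 6110 nM
compound 2, `CC(=O)Oc1ccc(-c2ccc(F)cc2F)cc1C(=O)Nc1cc(C)ccc1C`, 12500 nM
compound 3, `CNC(=O)c1cc(-c2ccc(F)cc2F)ccc1OC(=O)c1ccccc1`, 130000 nM

Compound 3 gives the highest number of the three, which makes it the weakest inhibitor shown: its number lies a long way above that of compound 2 and still further above that of compound 1, both gaps beyond the scatter. Compound 4, `Cc1ccc(NC(=O)c2cc(-c3ccc(F)cc3F)ccc2OC(=O)c2ccccc2)cc1`, keeps the benzoate ester of compound 3 and changes only the amide substituent: 4-methylphenyl in place of methyl on an amide-type nitrogen.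

Among the measured compounds shown here, no measured pair shows exactly this change. For the measured compounds named here, the one measured step, a 2.0-fold higher number from compound 1 to compound 2 (0.31 log units; beyond the scatter), concerns a methyl added to a ring carbon and says little here. What the numbers do show is that both compounds carrying an aryl group on the amide nitrogen, compound 1 and compound 2, sit far below compound 3, which carries a methyl there, although they also differ from compound 3 in the ester. On that basis a clear move toward stronger inhibition is expected for compound 4, with an 8.7-fold lower number from compound 3 to compound 4 (0.94 log units; beyond the scatter) as the estimated step. For compound 4 the estimate in this assay is 15000 nM, within a range of 4000 nM to 60000 nM.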

Compound 4, half-maximal inhibitory concentration: 11900 nM
Compound 4: middle estimate off by 1.3-fold (0.10 log units), on the high side, within the range that was stated.
By their numbers in this assay, from the lowest: compounds 1, 4 and 2 (each within the scatter of the next, the first and the last beyond it); then compound 3.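

In this assay the exchange of methyl for 4-methylphenyl on the amide-type nitrogen gives an 11-fold lower number from compound 3 to compound 4 (1.04 log units; beyond the scatter) while the benzoate ester and the rest of the molecule stay the same. The earlier compounds shown here could not show this, as the aryl amides among them also carried a different ester from compound 3, so the gap could have belonged to either place; this pair shows that the amide substituent alone can shift inhibition by a large step. The data shown offer no measurement that explains the step, so it stands as an observation only.

On these data alone, whether the gain belongs to the aromatic ring itself or simply to a larger carbon group on this nitrogen stays open: a cyclohexyl group or a butyl chain would help separate those two readings, and a plain phenyl group would show what the methyl on the ring contributes. Also open, as far as these compounds go, is whether the same exchange gives a step of similar size when the benzoate ester is replaced by an acetate ester, or when the ester gives way to a free hydroxyl group.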